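This account rests on a few compounds, and the source may have more. Where it says the series, first, only, none or still open, it means among the compounds named here.

Compound 1 `O=C(N[C@H]1CC[C@H](Nc2cc(-c3csc(NCC4CCOCC4)n3)c(Cl)cn2)CC1)C1CC1`: > 10000 nM, a limit of the assay
Compound 2 `COC[C@H](C)N[C@H]1CC[C@H](Nc2cc(-c3csc(NCC4CCOCC4)n3)c(Cl)cn2)CC1`: 440 nM

Within the data shown here, in a functional assay on MV4-11 cells (Homo sapiens) for antiproliferative activity, read by CellTiter-Glo, with a stated time of 72 h (a lower number here means a stronger inhibitor of growth, a higher number a weaker inhibitor of growth), compound 2 gives 440 nM, the only actual number so far. Compound 3 `COC[C@@H](C)N[C@H]1CC[C@H](Nc2cc(-c3csc(NCC4CCOCC4)n3)c(Cl)cn2)CC1` has not yet been measured. It differs from compound 2 as follows: the two compounds have the same atoms and bonds and differ only in configuration as drawn: 2 of 3 stereo elements differ; a stereocentre at a saturated chain carbon is drawn S in compound 2 and R in compound 3; a stereocentre at a saturated ring carbon is drawn S in compound 2 and R in compound 3. Among the measured compounds shown here, the single measured step, an at least 22-fold lower number from compound 1 to compound 2 (1.35 log units; beyond the scatter), is large, but it exchanges cyclopropylcarbonyl for 1-(methoxymethyl)ethyl on an amine nitrogen. It therefore gives no direct measure of a change in configuration. With no measured guide to direction, no shift beyond the scatter is expected in this assay. The expected change is a 1.1-fold higher number from compound 2 to compound 3 (0.06 log units; within the scatter). For compound 3 the estimate is 500 nM, within an expected range of 150 nM to 1800 nM.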

Compound 3, concentration for 50% growth inhibition: 140 nM
Estimate against measurement, compound 3: 3.6-fold (0.55 log units) above; measured number below the stated range.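

In this assay, configuration alone moves the number beyond the scatter, with a 3.1-fold lower number from compound 2 to compound 3 (0.50 log units; beyond the scatter), a size of effect that the earlier exchange of groups could not isolate: the fact that compounds 2 and 3 differ only in the configuration as drawn

The 1-(methoxymethyl)ethyl group in place of cyclopropylcarbonyl on the amine nitrogen also gives a large step in the other configuration, with an at least 71-fold lower number from compound 1 to compound 3 (1.85 log units; beyond the scatter). Compound 1 stands at a limit of the assay, not at a number: the limit of > 10000 nM in this assay, at which 1 of the 3 values shown sits.

The compounds shown leave open which of the two differently drawn stereocentres carries the step. They also leave open how a hydroxyl in place of the methoxy group, or a longer chain on that amine nitrogen, would read.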